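This account rests on a few compounds, and the source may have more. Where it says the series, first, only, none or still open, it means among the compounds named here.

Measured in a functional assay on HeLa cells (Homo sapiens) for inhibition, with a stated time of 72 h; a higher number here means a weaker inhibitor, a lower number a stronger inhibitor:
- Compound 1 `COc1ccccc1-c1ccc(CNc2nc(NC3CCC(N)CC3)nc3c2ncn3C2CCCC2)cc1`: 333 nM
- Compound 2 `NC1CCC(Nc2nc(NCc3ccc(-c4cccc(F)c4)cc3)c3ncn(C4CCCC4)c3n2)CC1`: 445 nM
- Compound 3 `NC1CCC(Nc2nc(NCc3ccc(-c4ccsc4)cc3)c3ncn(C4CCCC4)c3n2)CC1`: 220 nM

Compound 3, at 220 nM, stands within the scatter of compound 1 and clear of compound 2 only. Compound 4 `NC1CCC(Nc2nc(NCc3ccc(-c4ccsc4)nc3)c3ncn(C4CCCC4)c3n2)CC1` carries 6-(thiophen-3-yl)pyridin-3-yl in place of 4-(thiophen-3-yl)phenyl on a saturated chain carbon bound to a nitrogen on an aromatic ring.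

The nearest evidence is indirect. The measured steps, a 1.3-fold higher number from compound 1 to compound 2 (0.13 log units; within the scatter), a 1.5-fold lower number from compound 1 to compound 3 (0.18 log units; within the scatter) and a 2.0-fold lower number from compound 2 to compound 3 (0.31 log units; beyond the scatter), each exchange one aromatic group on an aromatic carbon, and none puts a nitrogen into a six-membered aromatic ring. They are small, so no shift beyond the scatter is expected in this assay. The expected step is a 1.1-fold higher number from compound 3 to compound 4 (0.06 log units; within the scatter). For compound 4 the estimate is 250 nM, with an expected range of 90 nM to 700 nM.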

Compound 4, half-maximal inhibitory concentration: 75 nM
Compound 4: middle estimate off by 3.3-fold (0.52 log units), on the high side; the whole stated range lies above it.
By their numbers in this assay, from the lowest: compound 4; then compounds 3, 1 and 2 (each within the scatter of the next, the first and the last beyond it).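

In this assay, the six-membered aromatic ring carrying the thiophen-3-yl group responds to a change within the ring itself: a nitrogen there, with its added hydrogen-bond acceptor, gives a 2.9-fold lower number from compound 3 to compound 4 (0.47 log units; beyond the scatter). The earlier steps shown here exchanged only the outer aromatic group, and only one of them went beyond the scatter. No measurement shown accounts for this gain.

On these data alone, whether a nitrile or an amine on that ring would keep the gain remains open. So does whether the ring nitrogen would give a similar step with 3-fluorophenyl in place of thiophen-3-yl.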